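Notes on the sulfonamide series, cytotoxicity on HEK293

The source may hold more compounds than are shown below. What is called first, only, known or untested is meant among the compounds shown, and "the series" means these compounds.

Measured so far:
compound 1, `CCS(=O)(=O)Nc1ccc(NC(=O)c2ccc(Cl)c([N+](=O)[O-])c2)cc1C`, 144000 nM in an ADME assay on HEK293 cells (Homo sapiens) for cytotoxicity, read by MTT assay, with a stated time of 48 h; a lower number here means a stronger inhibitor, a higher number a weaker inhibitor
compound 2, `Cc1cc(NC(=O)c2ccc(Cl)c([N+](=O)[O-])c2)ccc1NS(=O)(=O)C(F)(F)F`, > 250000 nM, a limit of this assay and not a number
compound 3, `CCS(=O)(=O)Nc1ccc(NC(=O)c2ccc(Cl)c([N+](=O)[O-])c2)cc1OC`, 63700 nM

Compound 3 stands lowest of the two numbers in this assay; the nearest is compound 1, which differs by a 2.3-fold lower number from compound 1 to compound 3 (0.35 log units; beyond the scatter). The third value shown is the limit of compound 2 (the limit of > 250000 nM in this assay, at which 1 of the 3 values shown sits).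

Compound 4, `COc1cc(NC(=O)c2ccc(Cl)c([N+](=O)[O-])c2)ccc1NS(=O)(=O)C(F)(F)F`, has not been measured. It differs from compound 3 by trifluoromethyl in place of ethyl on a sulfonyl sulfur. The same exchange has been measured once, from compound 1 to compound 2: an at least 1.7-fold higher number from compound 1 to compound 2 (0.23 log units; that floor lies within the scatter). That step ends at a limit, so only its floor is known, and that floor lies within the scatter.

For compound 4 in this assay the step of a 2.4-fold higher number from compound 3 to compound 4 (0.37 log units; beyond the scatter) is therefore expected, towards a higher number. The estimate for compound 4 is 150000 nM, between 55000 nM and 300000 nM, with a real chance that the assay again reports only a limit.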

Compound 4, half-maximal inhibitory concentration: > 250000 nM
Compound 4: a limit, no number (the forecaster's own chance of this, stated with the estimate: 35%); middle value at least 1.6-fold (0.22 log units) away from the limit.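

In this assay, trifluoromethyl in place of ethyl on a sulfonyl sulfur now gives an at least 3.9-fold higher number from compound 3 to compound 4 (0.59 log units; beyond the scatter), which clears the scatter, as the floor of the earlier exchange did not. Compound 2 and compound 4 both give a limit, so the step between them cannot be read, and the effect of methoxy in place of methyl is readable only with ethyl on the sulfonyl sulfur: the limit of > 250000 nM in this assay, at which 2 of the 4 values shown sit. The size of the exchange on the two cores therefore cannot be compared: the same change on two cores in this assay, an at least 1.7-fold higher number (0.23 log units; that floor lies within the scatter) from compound 1 to compound 2 and an at least 3.9-fold higher number (0.59 log units; beyond the scatter) from compound 3 to compound 4; the limit leaves it open whether they differ.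

Open, as far as these compounds go, are the numbers behind the limits of compound 2 and compound 4, and so whether methoxy in place of methyl acts with trifluoromethyl as it does with ethyl. Also open, from the compounds shown here alone, is where a longer chain such as propyl, or an amine, on the sulfonyl sulfur would fall in this assay.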